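This account rests on a few compounds, and the source may have more. Where it says the series, first, only, none or still open, it means among the compounds named here.

In a functional assay (plasma) with Oryctolagus cuniculus as the target (on this read-out higher numbers stand for weaker inhibition and lower numbers for stronger inhibition), compound 1 (`Cc1nc2cnccc2n1CC1CCN(C(=O)CNC(c2ccccc2)c2ccccc2)CC1`) gives 13 nM and compound 2 (`Cc1nc2cnccc2n1C1CCN(C(=O)CC(c2ccccc2)c2ccccc2)CC1`) gives 100 nM as the higher of the two numbers, so compound 2 is the weaker inhibitor of this pair, by a gap beyond the usual scatter. Compound 3 (`COC(=O)NC(CC(=O)N1CCC(n2c(C)nc3cnccc32)CC1)c1ccccc1`) has not been measured yet. Relative to compound 2 it carries (methoxycarbonyl)amino in place of phenyl on a saturated chain carbon bound to an aromatic carbon and a saturated chain carbon. Going by the values given here, no measured pair shows this change, and both measured compounds still carry the phenyl that leaves here. A moderate step in this assay towards a higher number is expected, starting from compound 2 at 100 nM and with wide uncertainty. The estimate amounts to a 2.0-fold higher number from compound 2 to compound 3 (0.30 log units; within the scatter) as an expected step. For compound 3 the estimated value is 200 nM within a range from 30 nM to 1500 nM for now.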

Compound 3, half-maximal inhibitory concentration: 1300 nM
Compound 3: the middle estimate sits 6.5-fold (0.81 log units) below what was measured; low and high end bracket the measured number.
By their numbers in this assay, from the lowest: compound 1; then compound 2; then compound 3.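

Replacing phenyl with (methoxycarbonyl)amino on a saturated chain carbon bound to an aromatic carbon and a saturated chain carbon gives a 13-fold higher number from compound 2 to compound 3 (1.11 log units; beyond the scatter) in this assay, so this position is not indifferent to the group it carries, and this exchange costs much inhibition. Going by these compounds alone, the single change removes a six-membered aromatic ring and brings in a ring-free group with a hydrogen-bond donor and hydrogen-bond acceptors, so the step cannot be assigned to the loss of one or the gain of the other. No supporting measurement bears on the reason for this step.

The compounds shown leave open how a cyclohexyl or a pyridyl would read at this carbon. A simple acetylamino group there would also show whether the methoxycarbonyl part matters on its own.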